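From Benzyl to 3-Fluorophenyl on the Amide-Type Nitrogen

A few compounds are considered here, and "the series" means these few. Any claim that something is new, unique, unknown or untested is made for them only; others in the source may bear on it.

Going by the values given here, compound 2 `CCOC(=O)c1cnn(CC(C)O)c1NC(=O)NCc1ccccc1` is the only member of this small set with a plain number: in a functional assay on cells (Neutrophil, Homo sapiens) for inhibition, with a stated time of 10 min (a higher number here means a weaker inhibitor, a lower number a stronger inhibitor), compound 2 gives 15 nM. Compound 1 `CCOC(=O)c1cnn(CC(C)O)c1NC(=O)Nc1ccc(F)cc1` differs from it by a 4-fluorophenyl in place of the benzyl on the amide-type nitrogen. For compound 1 this assay reports only a limit, > 10 nM. The step that the limit leaves unreadable from compound 1 to compound 2 therefore has no readable size, due to the limit of > 10 nM in this assay, at which 1 of the 2 values shown sits. Compound 3 `CCOC(=O)c1cnn(CC(C)O)c1NC(=O)Nc1cccc(F)c1` is the next analogue, and the change is 3-fluorophenyl in place of benzyl on an amide-type nitrogen. Among the compounds with values here, no measured step bears on this change in a readable way, so the expectation rests on the number for compound 2 and on the limit of compound 1, which also carries an aryl group on that nitrogen. Compound 3 is expected at 30 nM in this assay, with a range from 8 nM to 150 nM. The step of a 2.0-fold higher number from compound 2 to compound 3 (0.30 log units; within the scatter) is accordingly estimated as a small move towards weaker inhibition, not far beyond the scatter.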

Compound 3, half-maximal inhibitory concentration: > 10 nM
Compound 3 gave a limit, no number; the forecaster's own chance of this, stated with the estimate: 25%; the middle value is on the limit's open side.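

Going by these compounds alone, no step from compound 2 to compound 3 or from compound 1 to compound 3 can be read in this assay, due to this shared limit: the limit of > 10 nM in this assay, at which 2 of the 3 values shown sit.

Going by these compounds, how strongly compound 1 and compound 3 actually inhibit, and how either fluorophenyl group truly compares with benzyl on that nitrogen, remains open.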